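Shortening the Amide Chain from Compound 2 to Compound 4

The source may report more compounds than this note shows. Statements on the series, on what has been measured and on what is new or still open speak of the compounds shown alone.

Three compounds have been measured in an ADME assay on NCI-H460 cells (Homo sapiens) for cytotoxicity, read by MTT assay, with a stated time of 72 h; on this read-out higher numbers stand for weaker inhibition of growth and lower numbers for stronger inhibition of growth:
Compound 1 `CCCCNC(=O)C1C(C(=O)O)[C@@H]2CC[C@H]1O2` gives 10000 nM.
Compound 2 `CCCCCCCCCCNC(=O)C1C(C(=O)O)[C@@H]2CC[C@H]1O2` gives 10000 nM.
Compound 3 `CCc1ccccc1NC(=O)C1C(C(=O)O)[C@@H]2CC[C@H]1O2` gives 10000 nM.

Compound 2 stands level with compound 1 and compound 3 at the digits shown; none of the three separates from the others beyond the usual scatter. Within the data shown here, the only measured step that alters the chain on the amide nitrogen, no change at the digits printed from compound 1 to compound 2 (within the scatter), shows that adding a long run of saturated carbon there leaves the read-out where it was.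

Compound 4 `CCCNC(=O)C1C(C(=O)O)[C@@H]2CC[C@H]1O2` is the next compound to be tested in this assay. Its change from compound 2 is hydrogen in place of heptyl on a saturated chain carbon, three bonds along the chain from an amide-type nitrogen. Among the measured compounds shown here, this removes chain carbon rather than adding it, but the one step that bears on it, no change at the digits printed from compound 1 to compound 2 (within the scatter), was flat, so the step from compound 2 to compound 4 is expected to be no change at the digits printed from compound 2 to compound 4 (within the scatter). Compound 4 is therefore estimated at 10000 nM, within a range from 5000 nM to 20000 nM.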

Compound 4, concentration for 50% growth inhibition: 10000 nM
Estimate against measurement, compound 4: no gap at the digits printed, within the range that was stated.
By their numbers in this assay, from the lowest: compounds 1, 2, 3 and 4 (each within the scatter of the next).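

In this assay the chain on the amide nitrogen has now been shortened as well as lengthened: the result is no change at the digits printed from compound 2 to compound 4 (within the scatter) when heptyl gives way to hydrogen, and no change at the digits printed from compound 1 to compound 4 (within the scatter) when methyl gives way to hydrogen. The earlier step covered only added saturated carbon, whereas these two show that removing such carbon, whether a long stretch or a single methyl, also leaves the read-out level among these compounds. No measured evidence accounts for this flat result.

The compounds shown leave open whether anything placed on this chain can move the read-out, since all the chains compared here are plain saturated carbon. Going by these compounds, a chain ending in an amine or a hydroxyl group is not among them, so its effect remains unknown.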